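The source may hold more compounds than are shown below. What is called first, only, known or untested is meant among the compounds shown, and "the series" means these compounds.

Measured compounds and their values:
compound 1 `CCCCCCCC/C=C\CCCCCCCC(=O)N[C@H]1[C@@H](OCCCCCCCC)O[C@H](CO)[C@@H](O)[C@@H]1O` with 12 uM
compound 2 `CCCCC(=O)N[C@H]1[C@@H](OCCc2ccccc2)O[C@H](COCC(CO)(CO)COS(=O)(=O)O)[C@@H](O)[C@@H]1O` with 8.6 uM
compound 3 `CCCCCCCC/C=C\CCCCCCCC(=O)N[C@H]1[C@@H](OCCCCCCCC)O[C@H](COCC(CO)(CO)CO)[C@@H](O)[C@@H]1O` with 11.9 uM

In a functional assay on C6 cells (Rattus norvegicus), read by thymidine incorporation (on this read-out higher numbers stand for weaker inhibition and lower numbers for stronger inhibition), compound 1 gives the highest of the three numbers, but none of the three stands apart: its nearest neighbour is compound 3 and the step of a 1.0-fold lower number from compound 1 to compound 3 (0.00 log units; within the scatter), and even compound 2 lies within the scatter of it. The unmeasured compound 4 `CCCCCCCC/C=C\CCCCCCCC(=O)N[C@H]1[C@@H](OCCCCCCCC)O[C@H](CO)[C@@H](O)[C@@H]1OS(=O)(=O)O` differs from compound 1 by sulfo in place of hydrogen on an oxygen on a saturated carbon; read one bond further out, the change is hydroxy to sulfooxy.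

Going by the values given here, no measured step follows this exact change. Among the compounds with values here, the only step that shares a feature with it is the addition at an oxygen on a saturated carbon, the step from compound 1 to compound 3, which left the number unchanged. Compound 2 carries a sulfo group too, yet it also differs from compound 1 in its amide chain, its ether chain and the 3-hydroxy-2,2-bis(hydroxymethyl)propyl group. Within the data shown here, its value therefore shows only that a sulfo-bearing compound, compound 2, reaches 8.6 uM. With so little to build on, the expectation is that the step of a 1.2-fold lower number from compound 1 to compound 4 (0.08 log units; within the scatter) stays within the scatter. Compound 4 is therefore estimated at 10 uM, with a range from 4 uM to 25 uM.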

Compound 4, concentration for 50% inhibition: 5.4 uM
Compound 4: middle estimate off by 1.9-fold (0.27 log units), on the high side, within the range that was stated.
By their numbers in this assay, from the lowest: compounds 4, 2, 3 and 1 (each within the scatter of the next, the first and the last beyond it).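

In this assay, going by these compounds alone, putting sulfo in place of hydrogen on an oxygen on a saturated carbon gives a 2.2-fold lower number from compound 1 to compound 4 (0.35 log units; beyond the scatter), a modest change but the only step here that goes beyond the usual scatter. The earlier step, a 1.0-fold lower number from compound 1 to compound 3 (0.00 log units; within the scatter), had shown that a large addition at an oxygen of the core can leave the number unchanged, whereas this result shows that the number does respond to a change at an oxygen, although the two steps differ in both the group and the oxygen involved, so neither factor can be credited on its own. Nothing available here explains why the number falls.

On these data alone, it remains open whether the sulfooxy group itself matters or whether a carboxylic acid or a simple methyl ether on the same oxygen would give a similar number. Also open, as far as these compounds go, is whether sulfo on another oxygen of the core would have the same effect, since compound 2 differs from compound 1 in several places and so cannot answer this.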